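The source may hold more compounds than are shown below. What is called first, only, known or untested is meant among the compounds shown, and "the series" means these compounds.

For the measured compounds named here, compound 2 `COc1ccccc1-c1nc2cc(C(F)(F)F)ccc2[nH]1` stands lowest of the two numbers measured so far. In a functional assay on aorta (Rattus norvegicus, strain Wistar) for inhibition, with a stated time of 60 min (on this read-out lower numbers stand for smaller maximal responses and higher numbers for larger maximal responses), compound 1 `FC(F)(F)c1ccc2[nH]c(-c3ccccc3)nc2c1` gives 91.2%, while compound 2 gives 75.1%, a step of a number 16.1 percentage points lower from compound 1 to compound 2 (beyond the scatter). Compound 3 `CCOc1ccccc1-c1nc2cc(C(F)(F)F)ccc2[nH]1` differs from compound 2 by methyl in place of hydrogen on a saturated chain carbon bound to an oxygen on an aromatic ring. Going by the values given here, the one measured step concerns a methoxy entering where hydrogen stood, not methoxy growing to ethoxy, so it bears on the new step only loosely; with nothing else known, a small change is expected, a number 5.1 percentage points lower from compound 2 to compound 3 (within the scatter), possibly within the scatter. Compound 3 is therefore estimated at 70%, between 55% and 85%.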

Compound 3, largest response reached (Emax), in percent of the reference or control that the assay uses: 91%
Compound 3: middle estimate off by 21 percentage points, on the low side; measured number above the stated range.
By their numbers in this assay, from the lowest: compound 2; then compounds 3 and 1 (each within the scatter of the next).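

Going from methoxy to ethoxy adds one methyl on the saturated chain carbon bound to an oxygen on an aromatic ring, and in this assay this gives a number 15.9 percentage points higher from compound 2 to compound 3 (beyond the scatter), so even this small addition can change the result. Ethoxy in place of hydrogen on the aromatic carbon gives a number 0.2 percentage points lower from compound 1 to compound 3 (within the scatter), so the lower number seen with methoxy does not carry over to ethoxy. Nothing available explains this difference between the two groups. As far as these compounds go, whether a longer chain, such as propoxy, would behave like methoxy or like ethoxy stays open, as does the effect of an amine at this place.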